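The compounds below may be only part of what the source reports. "The series", "measured", "known", "first", "only" and "open" are said of these compounds alone.

Compound 3 `COc1ccc(C(=O)/C=C/c2cc(-c3cc(OC)c(OC)c(OC)c3)n[nH]2)cc1` gives 1730 nM in a functional assay on HCT-116 cells (Homo sapiens) for inhibition, read by sulforhodamine B assay, with a stated time of 48 h; on this read-out lower numbers stand for stronger inhibition of growth and higher numbers for weaker inhibition of growth; on the numbers shown it sits closest to compound 1 `COc1cc(-c2cc(/C=C/C(=O)c3ccc(Cl)c(Cl)c3)[nH]n2)cc(OC)c1OC` at 2950 nM, within the scatter of it, and furthest from compound 2 `COc1ccc(C(=O)/C=C/c2cc(-c3cc(OC)c(OC)c(OC)c3)n[nH]2)cc1OC` at 880 nM. Compound 4 `COc1cc(-c2cc(/C=C/C(=O)c3ccc(F)c(F)c3)[nH]n2)cc(OC)c1OC` differs from compound 3 by 3,4-difluorophenyl in place of 4-methoxyphenyl on a carbonyl carbon. Within the data shown here, the steps that bear on this swap at the carbonyl carbon are a 1.7-fold lower number from compound 1 to compound 3 (0.23 log units; within the scatter), which exchanges 3,4-dichlorophenyl for 4-methoxyphenyl, and a 3.4-fold lower number from compound 1 to compound 2 (0.53 log units; beyond the scatter). Going back from 4-methoxyphenyl to a ring carrying two halogens, 3,4-difluorophenyl, compound 4 is therefore expected to show a step of about a 1.4-fold higher number from compound 3 to compound 4 (0.16 log units; within the scatter), small and possibly within the scatter. Compound 4 is estimated at 2500 nM, with a range of 1000 nM to 6000 nM.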

Compound 4, concentration for 50% growth inhibition: 4000 nM
Estimate against measurement, compound 4: 1.6-fold (0.20 log units) below, and the stated range covers the measured number.
By their numbers in this assay, from the lowest: compounds 2, 3, 1 and 4 (each within the scatter of the next, the first and the last beyond it).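

In this assay the change from 3,4-dichlorophenyl to 3,4-difluorophenyl on the carbonyl carbon reads a 1.4-fold higher number from compound 1 to compound 4 (0.13 log units; within the scatter) and leaves these two halogen-bearing rings unseparated. The methoxy-bearing rings do separate from 3,4-difluorophenyl, with a 2.3-fold higher number from compound 3 to compound 4 (0.36 log units; beyond the scatter) and a 4.5-fold higher number from compound 2 to compound 4 (0.66 log units; beyond the scatter) both beyond the scatter, a split that 3,4-dichlorophenyl showed only against 3,4-dimethoxyphenyl. No available evidence accounts for these steps.

Still open, on these data alone, is how an amine, a carboxylic acid or a single chlorine on this ring would compare with the methoxy-bearing and halogen-bearing rings.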